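The compounds below may be only part of what the source reports. "The series", "measured", "known", "first", "only" and "open" are said of these compounds alone.

Working notes on the series. In a functional assay on A549 cells (Homo sapiens) for inhibition, read by CCK-8 assay, with a stated time of 72 h, tested at 1 uM (a higher number here means more inhibition of growth at the concentration tested, a lower number less inhibition of growth), compound 1 `Cc1ccc(NC(=O)C2(C(=O)Nc3ccc(Nc4ncc5cc(C(=O)N(C)C)n(C6CCCC6)c5n4)cc3)CC2)cc1` gives 40.2%, compound 2 `COC(=O)c1cccc(NC(=O)C2(C(=O)Nc3ccc(Nc4ncc5cc(C(=O)N(C)C)n(C6CCCC6)c5n4)cc3)CC2)c1` gives 10.5% and compound 3 `CN(C)C(=O)c1cc2cnc(Nc3ccc(NC(=O)C4(C(=O)Nc5cccc(C(F)(F)F)c5)CC4)cc3)nc2n1C1CCCC1` gives 15.7%. Compound 3 therefore sits level with compound 2 and clearly under compound 1. Next is compound 4 `COc1cccc(NC(=O)C2(C(=O)Nc3ccc(Nc4ncc5cc(C(=O)N(C)C)n(C6CCCC6)c5n4)cc3)CC2)c1`, with the difference methoxy in place of trifluoromethyl on an aromatic carbon, meta to a large group. Among the compounds with values here, the closest precedent is a swap at that same place, a number 5.2 percentage points higher from compound 2 to compound 3 (within the scatter). The larger steps, a number 29.7 percentage points lower from compound 1 to compound 2 (beyond the scatter) and a number 24.5 percentage points lower from compound 1 to compound 3 (beyond the scatter), exchange the whole substituted phenyl group, so they bear less directly. No step beyond the scatter is expected in this assay. The expected step is a number 4.3 percentage points higher from compound 3 to compound 4 (within the scatter). For compound 4 the estimate is 20%, with an expected range of 8% to 36%.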

Compound 4, percent growth inhibition at one concentration: 77.2%
Compound 4: middle estimate off by 57.2 percentage points, on the low side; the measured number lies above the stated range.
By their numbers in this assay, from the lowest: compounds 2 and 3 (each within the scatter of the next); then compound 1; then compound 4.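

In this assay, the aromatic carbon meta to a large group proves highly sensitive to its substituent: methoxy gives a number 61.5 percentage points higher from compound 3 to compound 4 (beyond the scatter) and a number 66.7 percentage points higher from compound 2 to compound 4 (beyond the scatter), whereas trifluoromethyl and methoxycarbonyl there remained within the scatter of each other. The 3-methoxyphenyl group also outperforms 4-methylphenyl, with a number 37 percentage points higher from compound 1 to compound 4 (beyond the scatter), making compound 4 the most active of the four. No available evidence accounts for this gain. The compounds shown leave open whether ethoxy or hydroxy at the same carbon would retain the gain. They also leave open whether methoxy would do so elsewhere on this ring.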